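The source may report more compounds than this note shows. Statements on the series, on what has been measured and on what is new or still open speak of the compounds shown alone.

Measured so far:
Compound 1, `Cc1ncc([N+](=O)[O-])n1CCSc1nnc(-c2ccccc2O)o1`, 19600 nM
Compound 2, `COc1ccc(-c2nnc(SCCn3c([N+](=O)[O-])cnc3C)o2)c(O)c1`, 11000 nM
Compound 3, `COc1cc(OC)cc(-c2nnc(SCCn3c([N+](=O)[O-])cnc3C)o2)c1`, 10500 nM

All three were run in a functional assay on HepG2 cells (Homo sapiens) for cytotoxicity, read by MTT assay, with a stated time of 48 h; a lower number here means a stronger inhibitor, a higher number a weaker inhibitor. Compound 1 gives 19600 nM, compound 2 gives 11000 nM and compound 3 gives 10500 nM in this assay. Compound 1 and compound 2 differ in one place, (methoxy in place of hydrogen on an aromatic carbon), and that change brought a 1.8-fold lower number from compound 1 to compound 2 (0.25 log units; within the scatter).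

Compound 4, `COc1cc(-c2nnc(SCCn3c([N+](=O)[O-])cnc3C)o2)cc(OC)c1OC`, has not yet been measured. It is related to compound 3 by the same kind of change, (methoxy in place of hydrogen on an aromatic carbon). The surroundings are not identical: in compound 2 the entering group sits meta to a hydroxy group (1 heavy atom) and para to a large group, whereas in compound 4 it sits ortho to two methoxy groups (2 heavy atoms each) and para to a large group. How the core of compound 3 differs from the core of compound 1 is not broken down here; the values of compound 1 and compound 3 in this assay lie within the scatter of each other.

The expectation for compound 4 rests on the step of a 1.8-fold lower number from compound 1 to compound 2 (0.25 log units; within the scatter), which stayed within the scatter. The step expected in this assay is accordingly small, a 1.3-fold lower number from compound 3 to compound 4 (0.12 log units; within the scatter). For compound 4 the estimate in this assay is 8000 nM, expected to lie between 4000 nM and 20000 nM.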

Compound 4, half-maximal inhibitory concentration: 14900 nM
Estimate against measurement, compound 4: 1.9-fold (0.27 log units) below, within the range that was stated.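

In this assay, methoxy in place of hydrogen on an aromatic carbon, here ortho to two methoxy groups and para to a large group, gives a 1.4-fold higher number from compound 3 to compound 4 (0.15 log units; within the scatter). The two steps for this change carry opposite signs as printed, but neither lies beyond the scatter, and neither does the gap between them: the same change on two cores in this assay, a 1.8-fold lower number (0.25 log units; within the scatter) from compound 1 to compound 2 and a 1.4-fold higher number (0.15 log units; within the scatter) from compound 3 to compound 4, 2.5-fold (0.40 log units) apart, within the scatter of two such steps The pair therefore shows that this change has not yet produced a step that stands clear of the scatter on either core, but it does not show that the change carries over from one core to the other with a shared size or direction, nor that the outcome depends on the core, and the surroundings of the entering methoxy group also differ between the two cases.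

The compounds shown leave open whether any group on the aromatic ring can move the number in this assay beyond the scatter, for instance an amine or a carboxylic acid in place of methoxy. They also leave open whether a longer chain joining the parts of the molecule would do so, and whether the methoxy step would look the same with such a chain in place.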